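The source may hold more compounds than are shown below. What is called first, only, known or untested is meant among the compounds shown, and "the series" means these compounds.

Compound 3, `Cc1ccc(CSc2ncnc3c2ncn3[C@@H]2O[C@H](CO)[C@@H](O)[C@H]2O)cc1`, gives 457 nM in an assay on isolated protein for binding affinity to Equilibrative nucleoside transporter 1 (Homo sapiens) (on this read-out lower numbers stand for stronger inhibition and higher numbers for weaker inhibition), and stands lowest of the three measured compounds. Compound 2, `Cc1cccc(CSc2ncnc3c2ncn3[C@@H]2O[C@H](CO)[C@@H](O)[C@H]2O)c1`, gives 12000 nM in this assay, and compound 1, `OC[C@H]1O[C@@H](n2cnc3c(NCc4ccco4)ncnc32)[C@H](O)[C@@H]1O`, gives 36300 nM. The steps to compound 3 are both beyond the scatter: a 26-fold lower number from compound 2 to compound 3 (1.42 log units; beyond the scatter), and a 79-fold lower number from compound 1 to compound 3 (1.90 log units; beyond the scatter); the step of a 3.0-fold lower number from compound 1 to compound 2 (0.48 log units; beyond the scatter) is modest by comparison.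

Compound 4, `OC[C@H]1O[C@@H](n2cnc3c(CSc4ccccc4I)ncnc32)[C@H](O)[C@@H]1O`, differs from compound 3 by a group of 9 heavy atoms (7 carbon, 1 sulfur, 1 iodine; one six-membered aromatic ring of carbon only) in place of a group of 9 heavy atoms (8 carbon, 1 sulfur; one six-membered aromatic ring of carbon only), on an aromatic carbon. The change is not a copy of any measured step. The step from compound 2 to compound 3 shows that moving the methyl on the six-membered ring of carbon only shifts this assay by a large amount, and the step from compound 1 to compound 3 shows that the whole group on that aromatic carbon matters greatly. Compound 4 alters both the arrangement of the sulfur and the carbon in its group and the ring substituent, so a sizeable step from the value of compound 3 is expected, most likely toward a higher number, with wide uncertainty. Compound 4 is therefore estimated at 2500 nM, within 250 nM to 25000 nM, an expected step of a 5.5-fold higher number from compound 3 to compound 4 (0.74 log units; beyond the scatter).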

Compound 4, half-maximal inhibitory concentration: 282 nM
The estimate for compound 4 lay 8.9-fold (0.95 log units) above the measured number; the range from low to high includes it.
By their numbers in this assay, from the lowest: compounds 4 and 3 (each within the scatter of the next); then compound 2; then compound 1.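

In this assay, replacing the (4-methylbenzyl)sulfanyl group with the iodine-bearing group of the same heavy-atom count gives a 1.6-fold lower number from compound 3 to compound 4 (0.21 log units; within the scatter), so compound 3 and compound 4 cannot be told apart, and this aromatic carbon accepts two different groups carrying a six-membered aromatic ring of carbon only at a similar level. The earlier compounds had shown only how much this position can cost: compound 2 also carries such a ring but stands well apart, with a 43-fold lower number from compound 2 to compound 4 (1.63 log units; beyond the scatter), so having that ring is not enough to reach this level, while a 130-fold lower number from compound 1 to compound 4 (2.11 log units; beyond the scatter) sets the iodine-bearing group far from the ((furan-2-yl)methyl)amino group. Nothing measured here explains why these two groups read alike in this assay.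

Because the iodine-bearing group differs from the (4-methylbenzyl)sulfanyl group both in what its ring carries and in how its sulfur and carbon are arranged, the compounds shown do not separate the contribution of either difference. They also leave open how an amine or a carboxylic acid on that ring, or a longer chain in place of the whole group, would read at this position.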